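The source may hold more compounds than are shown below. What is called first, only, known or untested is meant among the compounds shown, and "the series" means these compounds.

Measured in a functional assay on HepG2 cells (Homo sapiens) for inhibition, read by MTT assay, with a stated time of 3 days (on this read-out higher numbers stand for weaker inhibition and lower numbers for stronger inhibition), as follows:

Compound 1 `COc1cc(-c2nc3ccccc3s2)ccc1OCC(=O)NNC(=O)CCl` gives 2890 nM
Compound 2 `CCOC(=O)CN(C)CC(=O)NNC(=O)COc1ccc(-c2nc3ccccc3s2)cc1OC` gives 3180 nM
Compound 3 `CCOC(=O)[C@H](CS)N(CC(=O)NNC(=O)COc1ccc(-c2nc3ccccc3s2)cc1OC)C(C)=O` gives 3010 nM

Compound 3 stands at 3010 nM on this scale, within the scatter of both other compounds, so the three numbers set up no order. Compound 4 `CCOC(=O)[C@@H]1CCCN1CC(=O)NNC(=O)COc1ccc(-c2nc3ccccc3s2)cc1OC` differs from compound 3 by the change 2-(ethoxycarbonyl)pyrrolidin-1-yl in place of acetyl(1-(ethoxycarbonyl)-2-sulfanylethyl)amino on a saturated chain carbon bound to a carbonyl carbon on a saturated chain carbon bound to a carbonyl carbon.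

Three measured steps alter the group at this same place: a 1.1-fold higher number from compound 1 to compound 2 (0.04 log units; within the scatter) and a 1.0-fold higher number from compound 1 to compound 3 (0.02 log units; within the scatter) and also a 1.1-fold lower number from compound 2 to compound 3 (0.02 log units; within the scatter) (each small). None of the three measured compounds carries a ring at this place, so the data do not test that feature directly. Even so, the groups exchanged so far differ widely and the number has stayed put, so no step beyond the scatter is expected in this assay for this change. The step expected is a 1.0-fold lower number from compound 3 to compound 4 (0.00 log units; within the scatter) on this estimate. Compound 4 is expected at 3000 nM (range 1400 nM to 6500 nM).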

Compound 4, half-maximal inhibitory concentration: 2800 nM
Beside the measured number, compound 4's estimate is 1.1-fold (0.03 log units) above it; the range from low to high includes it.
By their numbers in this assay, from the lowest: compounds 4, 1, 3 and 2 (each within the scatter of the next).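

In this assay compound 4 carries a ring at this saturated chain carbon bound to a carbonyl carbon, which none of the other three compounds does, yet the number does not move: a 1.1-fold lower number from compound 3 to compound 4 (0.03 log units; within the scatter) and a 1.1-fold lower number from compound 2 to compound 4 (0.06 log units; within the scatter) and also a 1.0-fold lower number from compound 1 to compound 4 (0.01 log units; within the scatter) with each step within the scatter. A five-membered non-aromatic ring with 1 hetero atom can therefore enter this place, and the sulfanyl and acetyl groups of compound 3 can leave it, without setting up any order among the four compounds. Nothing measured here bears on why the number stays the same.

On these data alone, whether a carboxylic acid in place of the ethyl ester, or a piperidine or an aromatic ring at this place, would shift the number remains open. As far as these compounds go, all four compounds share one core, so what a change elsewhere in it would do also stays open.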